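One Stereocentre Turned: From Compound 1 to Compound 4

The source may hold more compounds than are shown below. What is called first, only, known or untested is meant among the compounds shown, and "the series" means these compounds.

Three compounds were measured in an assay on membranes from Chem-1 cells for displacement of a labelled ligand from prostaglandin E2 receptor EP3 subtype (Homo sapiens), read by scintillation counting, with a stated time of 2 h; on this read-out higher numbers stand for weaker inhibition and lower numbers for stronger inhibition:

compound 1 `CC(C)[C@@H](C[C@H]1SC(=O)NC1=O)c1ccc(-c2ccc3cccc(F)c3c2)[nH]c1=O` — 6 nM
compound 2 `CCc1cccc2ccc(-c3ccc(C(/C=C4\OC(=O)NC4=O)(CC)CC)c(=O)[nH]3)cc12` — 17 nM
compound 3 `CCC(/C=C1\OC(=O)NC1=O)(CC)c1ccc(-c2ccc3cccc(C(F)(F)F)c3c2)[nH]c1=O` — 230 nM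

Compound 1 gives the lowest number of the three. Its nearest neighbour is compound 2, whose number is higher by an amount beyond the scatter, and the furthest is compound 3, which stands far higher still. The only single-change step among these three is a 14-fold higher number from compound 2 to compound 3 (1.13 log units; beyond the scatter), a trifluoromethyl in place of ethyl on an aromatic carbon; it tells nothing about configuration.

Compound 4 `CC(C)[C@H](C[C@H]1SC(=O)NC1=O)c1ccc(-c2ccc3cccc(F)c3c2)[nH]c1=O` is the next compound to be measured. It differs from compound 1 in this way: the two compounds have the same atoms and bonds and differ only in configuration as drawn: 1 of 2 stereo elements differ; a stereocentre at a saturated chain carbon is drawn R in compound 1 and S in compound 4. Among the compounds with values here, no measured step here concerns a stereocentre, so the size of the effect cannot be read from the three values shown; the shared core and both aryl groups are kept unchanged. Because compound 1 gives the lowest number with 6 nM, the configuration drawn there is taken as the favourable one, and the inverted centre in compound 4 is expected to shift the number upward, by an estimated 6.7-fold higher number from compound 1 to compound 4 (0.82 log units; beyond the scatter), with wide uncertainty about how far. The estimate for compound 4 in this assay is 40 nM, within a range from 6 nM to 300 nM.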

Compound 4, inhibition constant: 8 nM
Compound 4: the middle estimate sits 5.0-fold (0.70 log units) above what was measured, and the stated range covers the measured number.
By their numbers in this assay, from the lowest: compounds 1 and 4 (each within the scatter of the next); then compound 2; then compound 3.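

In this assay inverting the saturated chain carbon, drawn R in compound 1 and S in compound 4, gives a 1.3-fold higher number from compound 1 to compound 4 (0.12 log units; within the scatter). Within the data shown here, this is the first step in the set that concerns a stereocentre, and it shows that, with the second stereocentre and the rest of the structure held as drawn, this read-out does not separate the two configurations at this position. The step can be read as a test of that one centre alone, because nothing else distinguishes the pair: the fact that compounds 1 and 4 differ only in the configuration as drawn.

The compounds shown leave open whether the second stereocentre, drawn alike in compound 1 and compound 4, would prove as indifferent, since no pair here inverts it. They also leave open whether the two configurations at the chain carbon would still lie within the scatter of each other if the isopropyl group on that carbon were replaced by a longer chain or an amine, or if the fluoro substituent on the aryl group were replaced by a nitrile.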